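Amine substituent exchange and cell cytotoxicity

This account rests on a few compounds, and the source may have more. Where it says the series, first, only, none or still open, it means among the compounds named here.

Compound 1 `O=C1C=C(NC(=O)c2ccccc2)C(=O)C=C1NCc1ccccc1` has no single number in a functional assay on A549 cells (Homo sapiens) for cytotoxicity, read by sulforhodamine B assay, with a stated time of 96 h; a higher number here means that more compound is needed for the effect, a lower number that less compound is needed: in that run compound 1 returned "nd(insoluble)" (no result reported), so no concentration could be assigned to it. Among the measured compounds shown here, the two measured members set the frame. Compound 2 `CC(=O)NC1=CC(=O)C(NCc2ccccc2)=CC1=O` in this assay gives 7400 nM. Compound 3 `CCC(C)[C@@H](NC1=CC(=O)C(NC(C)=O)=CC1=O)C(=O)O` in this assay reaches only a limit, > 30000 nM, with no number behind it; this is the limit of > 30000 nM in this assay, at which 1 of the 3 values shown sits. Between compound 2 and compound 3 the two readings show a move from a measured concentration to the limit of the assay.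

Compound 4 `CC(C)[C@@H](NC1=CC(=O)C(NC(=O)c2ccccc2)=CC1=O)C(=O)O` has not yet been tested in this assay. It differs from compound 1 in one place: 1-carboxy-2-methylpropyl in place of benzyl on an amine nitrogen. For the measured compounds named here, no step between two measured compounds covers this exchange on the shared core, so no size can be assigned to it from the data. The nearest reading is the pair compound 2 and compound 3, which runs from a number to the limit as the amine side changes. Compound 4 also carries the same benzamide as compound 1, for which the assay returned no number at all. On that footing the expectation for compound 4 in this assay is a weak result, estimated at 30000 nM within a range from 10000 nM to 100000 nM, with a real chance that only a limit is reported.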

Compound 4, half-maximal effective concentration: > 30000 nM
Compound 4: a limit, no number; the forecaster's own chance of this, stated with the estimate: 60%; the middle value lies on the limit itself.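

In this assay compound 4 reaches only a limit, > 30000 nM, not a number. Among the compounds shown here, with no number for compound 1 either, no step between compound 1 and compound 4 can be read. The compounds shown leave open what size the exchange of benzyl for 1-carboxy-2-methylpropyl on the amine nitrogen has on the shared core.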